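The source may hold more compounds than are shown below. What is called first, only, known or untested is meant among the compounds shown, and "the series" means these compounds.

Measured so far in an assay for inhibition of cytokinin dehydrogenase 2 (Arabidopsis thaliana); a lower number here means a stronger inhibitor, a higher number a weaker inhibitor:

Compound 1 `COc1cccc(Nc2nc(SC)nc3[nH]cnc23)c1`: > 100000 nM
Compound 2 `COc1ccc(Nc2nc(Cl)nc3[nH]cnc23)cc1`: > 100000 nM
Compound 3 `Fc1cccc(Nc2nc(Cl)nc3[nH]cnc23)c1`: 7500 nM

Compound 1 gives only a limit, > 100000 nM. Compound 2 likewise gives only a limit, > 100000 nM. Compound 3 stands alone with an actual number, 7500 nM. Compounds 1 and 2 give only limits (the limit of > 100000 nM in this assay, at which 2 of the 3 values shown sit). Going by the values given here, no pair of measured compounds differs in a single place, so no measured step is available.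

Compound 4 `COc1cccc(Nc2nc(Cl)nc3[nH]cnc23)c1` differs from compound 3 by methoxy in place of fluoro on an aromatic carbon. Going from compound 3 to compound 4, a loss of potency beyond the usual scatter is expected, an 8.0-fold higher number from compound 3 to compound 4 (0.90 log units; beyond the scatter), with a fair chance that this assay reports only a limit. Compound 4 is estimated at 60000 nM, within 8000 nM to 300000 nM.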

Compound 4, half-maximal inhibitory concentration: 1900 nM
Compound 4: middle estimate off by 32-fold (1.50 log units), on the high side, and the stated range ends above it.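

In this assay, methoxy in place of fluoro at this position, meta to a large group, does not cost potency but gains it, giving a 3.9-fold lower number from compound 3 to compound 4 (0.60 log units; beyond the scatter). With that methoxy kept, chloro in place of methylsulfanyl gives an at least 52-fold lower number from compound 1 to compound 4 (1.72 log units; beyond the scatter), so a second place on the core also matters. The size of that second step is only a minimum, resting on a limit for compound 1: the limit of > 100000 nM in this assay, at which 2 of the 4 values shown sit.

Going by these compounds, how an amine or a longer chain such as ethoxy would fare at this position stays open.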